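A Phenyl in Place of a Methyl on a Shared Core

The source may report more compounds than this note shows. Statements on the series, on what has been measured and on what is new or still open speak of the compounds shown alone.

Of the compounds shown here, two built on closely related fused cores have been tested in an ADME assay on MRC5 cells (Homo sapiens) for antiproliferative activity, read by MTT assay, with a stated time of 48 h; a lower number here means a stronger inhibitor, a higher number a weaker inhibitor. Compound 1 `Cc1coc2c3c(ccc2c1=O)OC[C@H]1[C@@H]3C2=C(CCCC2=O)OC1(C)C` gives > 100000 nM in this assay, which is a limit of the assay and not a number. Compound 2 `Cc1nn(-c2ccccc2)c2c1[C@@H]1c3c(ccc4c(=O)c(C)c(C)oc34)OC[C@@H]1C(C)(C)O2` also reaches only a limit in this assay, > 100000 nM. For the measured compounds named here, both measured values therefore sit at the same place, as stated by the limit of > 100000 nM in this assay, at which 2 of the 2 values shown sit, and no step between measured compounds can be read from them.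

Compound 3 `Cc1nn(-c2ccccc2)c2c1[C@@H]1c3c(ccc4c(=O)c(-c5ccccc5)c(C)oc34)OC[C@@H]1C(C)(C)O2` is not yet measured. It differs from compound 2 by phenyl in place of methyl on an aromatic carbon. Going by the values given here, no measured step exists to guide the size of the change, and both known compounds show no activity down to the limit. The expectation is therefore that compound 3 stays at or near that limit, with the step of a number no higher from compound 2 to compound 3 (the limit leaves the size open) expected to be none beyond the scatter. Compound 3 is expected to give about 100000 nM in this assay, estimated to lie between 30000 nM and 300000 nM.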

Compound 3, half-maximal inhibitory concentration: > 100000 nM
Compound 3: a limit, no number; the forecaster's own chance of this, stated with the estimate: 70%; the middle value sits exactly at the limit.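

Compound 3 gives > 100000 nM in this assay, which is a limit of the assay and not a number. No step from compound 2 to compound 3 can be read, because both compounds end at the same limit: the limit of > 100000 nM in this assay, at which 3 of the 3 values shown sit.

The compounds shown leave open whether phenyl in place of methyl on an aromatic carbon changes antiproliferative activity at all.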